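Swapping Chloro for Nitro in a Weakly Cytotoxic Series

The compounds below may be only part of what the source reports. "The series", "measured", "known", "first", "only" and "open" are said of these compounds alone.

Of the compounds shown here, two sharing the same aryl-pyrrole fragment have been tested in an ADME assay on Vero cells (Chlorocebus sabaeus) for cytotoxicity, read by MTT assay, with a stated time of 72 h; a higher number here means a weaker inhibitor, a lower number a stronger inhibitor. Compound 1 `CC(=O)N1N=C(c2ccc(-n3c(C)ccc3C)cc2)OC1c1ccccc1Cl` gives 201000 nM. Compound 2 `CC(=O)NNC(=O)c1ccc(-n2c(C)ccc2C)cc1` differs from compound 1 in several places; in this assay compound 2 gives 173000 nM, and the gap between the two numbers lies within the usual scatter of repeated measurements, so neither can be called more or less toxic than the other on this evidence. Both numbers point to weak effects on the cells. Compound 3 `CC(=O)N1N=C(c2ccc(-n3c(C)ccc3C)cc2)OC1c1ccccc1[N+](=O)[O-]` has not yet been measured; it carries the change (nitro in place of chloro on an aromatic carbon). For the measured compounds named here, no measured pair shows what this swap does here, so the expectation must rest on the two numbers at hand. Compound 3 is estimated at 200000 nM in this assay, with a likely range from 100000 nM to 400000 nM. The expected step of a 1.0-fold lower number from compound 1 to compound 3 (0.00 log units; within the scatter) is no larger than the scatter, in no particular direction.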

Compound 3, half-maximal inhibitory concentration: 175000 nM
Compound 3: the middle estimate sits 1.1-fold (0.06 log units) above what was measured; measured number inside the range.
By their numbers in this assay, from the lowest: compounds 2, 3 and 1 (each within the scatter of the next).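

For the compounds shown here, the 2-chlorophenyl to 2-nitrophenyl change gives the first direct reading of a single swap at this position, on an aromatic carbon ortho to a large group. In this assay, it gives a 1.1-fold lower number from compound 1 to compound 3 (0.06 log units; within the scatter), so this pair shows no measurable effect on the number, even though nitro brings more heavy atoms and two hydrogen-bond acceptors that chloro lacks. No separate measurement bears on why the two compounds read alike.

The compounds shown leave open whether an amine or a carboxylic acid in this same place would give a number beyond the scatter. They also leave open whether the nitro for chloro swap would read the same way at another carbon of this ring.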